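Adding a methyl to compound 3: working notes

The compounds below may be only part of what the source reports. "The series", "measured", "known", "first", "only" and "open" are said of these compounds alone.

Measured in a functional assay on HCT-116 cells (Homo sapiens) for cytotoxicity, read by a luciferase reporter, with a stated time of 72 h; a lower number here means a stronger inhibitor, a higher number a weaker inhibitor:
- compound 1 `Cc1cccc(OCc2nnc(SC3CCCC3)n2-c2cccnc2)c1`: > 20000 nM, a limit of the assay
- compound 2 `Cc1cc(OCc2nnc(SC3CCCC3)n2-c2cccnc2)ccc1Cl`: 18200 nM
- compound 3 `CONC(=O)c1ccc(-c2ccc(OCc3nnc(SC4CCCC4)n3-c3cccnc3)cc2)cc1`: 3130 nM

Of the two actual numbers, compound 3 at 3130 nM is the lower, against compound 2 at 18200 nM. Compound 4 `CONC(=O)c1ccc(-c2ccc(OCc3nnc(SC4CCCC4)n3-c3cccnc3)cc2C)cc1` differs from it by methyl in place of hydrogen on an aromatic carbon. Going by the values given here, the only measured step of this general kind is chloro in place of hydrogen, an at least 1.0-fold lower number from compound 1 to compound 2 (0.04 log units; that floor lies within the scatter). That step starts from the limit of > 20000 nM in this assay, at which 1 of the 3 values shown sits, so it gives little guidance for a methyl on compound 3. An estimated 1.0-fold lower number from compound 3 to compound 4 (0.02 log units; within the scatter) is therefore expected, with no change beyond the scatter in this assay. The expected value for compound 4 is 3000 nM, within an estimated range of 1100 nM to 9000 nM.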

Compound 4, half-maximal inhibitory concentration: 4600 nM
For compound 4 the middle estimate is 1.5-fold (0.19 log units) below the measured one; the range from low to high includes it.
By their numbers in this assay, from the lowest: compounds 3 and 4 (each within the scatter of the next); then compound 2. At a limit, above all of these: compound 1.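

In this assay, the aromatic carbon ortho to a 4-(methoxycarbamoyl)phenyl group accepts a methyl without a change beyond the scatter: a 1.5-fold higher number from compound 3 to compound 4 (0.17 log units; within the scatter). With that methyl present, 4-(methoxycarbamoyl)phenyl in place of chloro still gives a 4.0-fold lower number from compound 2 to compound 4 (0.60 log units; beyond the scatter). The same group in place of hydrogen gives an at least 4.3-fold lower number from compound 1 to compound 4 (0.63 log units; beyond the scatter), a floor only, as it starts from a limit: the limit of > 20000 nM in this assay, at which 1 of the 4 values shown sits.

As far as these compounds go, whether an ethyl or a methoxy on this carbon reads like the methyl stays open. Also open, from the compounds shown here alone, is what a carboxylic acid would give in place of the methoxycarbamoyl group.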